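Adding a second chlorine to the aryl group of compound 3

A few compounds are considered here, and "the series" means these few. Any claim that something is new, unique, unknown or untested is made for them only; others in the source may bear on it.

Of the compounds shown here, three share one core and have been measured in a functional assay on CHO cells with adenosine receptor A1 (Homo sapiens) as the target, read by cAMP accumulation and immunoassay, with a stated time of 6 min, tested at 0.1 uM; a higher number here means a weaker effect of the compound at the concentration tested, a lower number a stronger effect. Compound 1 `Nc1scc(CN2CCN(c3cccc(Cl)c3Cl)CC2)c1C(=O)c1ccc(Cl)cc1` gives 3.2%. Compound 2 `Nc1scc(CN2CCN(CCCc3ccc(Cl)cc3)CC2)c1C(=O)c1ccc(Cl)cc1` gives -3%. Compound 3 `Nc1scc(CN2CCN(c3cccc(Cl)c3)CC2)c1C(=O)c1ccc(Cl)cc1` gives -20%, the lowest of the three numbers, since its steps to the others, a number 23.2 percentage points lower from compound 1 to compound 3 (beyond the scatter) and a number 17 percentage points lower from compound 2 to compound 3 (beyond the scatter), are both beyond the scatter.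

Compound 4 `Nc1scc(CN2CCN(c3ccc(Cl)c(Cl)c3)CC2)c1C(=O)c1ccc(Cl)cc1` is not yet measured. It differs from compound 3 by one change, (chloro in place of hydrogen on an aromatic carbon), placed on an aromatic carbon of a six-membered aromatic ring of carbon only, ortho to a chloro group and para to a large group.

The measured step that bears on this is a number 23.2 percentage points lower from compound 1 to compound 3 (beyond the scatter), where the chloro was taken away at another carbon of the same kind of ring and the number fell modestly. Read in the opposite direction, a chloro put back is expected to raise the number by a modest amount, so the step of a number 20 percentage points higher from compound 3 to compound 4 (beyond the scatter) is expected. Compound 4 is therefore estimated at 0%, within -15% to 15%.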

Compound 4, a percentage reported as activity, at one concentration (the size of the read-out at that concentration, not a potency): -13%
Beside the measured number, compound 4's estimate is 13 percentage points above it; the range from low to high includes it.
By their numbers in this assay, from the lowest: compounds 3, 4, 2 and 1 (each within the scatter of the next, the first and the last beyond it).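

In this assay, a chloro on this carbon, ortho to the existing chloro group and para to a large group, gives a step that cannot be told from no change (a number 7 percentage points higher from compound 3 to compound 4 (within the scatter)). Where the second chlorine sits does register, however, since 3,4-dichlorophenyl and 2,3-dichlorophenyl are separated by a step larger than the scatter (a number 16.2 percentage points lower from compound 1 to compound 4 (beyond the scatter)), while the swap from the 3-(4-chlorophenyl)propyl group to 3,4-dichlorophenyl stays inside it (a number 10 percentage points lower from compound 2 to compound 4 (within the scatter)). Nothing available explains why the two chlorine positions part in this way.

On these data alone, whether a fluoro, a methyl or a methoxy group on this same carbon would stay as close to compound 3 remains open. So does whether a larger group there, such as a phenyl ring, would move the number beyond the scatter.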